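Trifluoromethoxy for Trifluoromethyl on Two Related Cores

The compounds below may be only part of what the source reports. "The series", "measured", "known", "first", "only" and "open" are said of these compounds alone.

Measured compounds:
compound 1, `CC(O)(CSc1ccc(C(F)(F)F)cc1)C(=O)Nc1ccc(S(F)(F)(F)(F)F)cc1`, 24800 nM
compound 2, `CC(O)(CSc1ccc(OC(F)(F)F)cc1)C(=O)Nc1ccc(S(F)(F)(F)(F)F)cc1`, 16000 nM
compound 3, `CC(O)(CSc1ccccc1C(F)(F)F)C(=O)Nc1cccc(S(F)(F)(F)(F)F)c1`, 21000 nM

In a functional assay on VCaP cells (Homo sapiens) for antiproliferative activity, read by propidium iodide staining, with a stated time of 96 h (a lower number here means a stronger inhibitor, a higher number a weaker inhibitor), compound 1 gives 24800 nM. Compound 2 differs from compound 1 by trifluoromethoxy in place of trifluoromethyl on an aromatic carbon, and this change gave a 1.6-fold lower number from compound 1 to compound 2 (0.19 log units; within the scatter). Compound 3 has the same atoms as compound 1, joined differently; the difference between the two cores is not broken down here. In this assay compound 3 gives 21000 nM, and its number and that of compound 1 lie within the scatter of each other.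

Compound 4, `CC(O)(CSc1ccccc1OC(F)(F)F)C(=O)Nc1cccc(S(F)(F)(F)(F)F)c1`, is not yet measured. It differs from compound 3 by trifluoromethoxy in place of trifluoromethyl on an aromatic carbon. This is the same kind of change as that from compound 1 to compound 2, but the place is not identical: there the group sat para to a large group, here it sits ortho to a large group. Because a 1.6-fold lower number from compound 1 to compound 2 (0.19 log units; within the scatter) was within the scatter, a step of a 1.5-fold lower number from compound 3 to compound 4 (0.18 log units; within the scatter) is expected. Compound 4 is therefore estimated to give 14000 nM, somewhere between 7000 nM and 35000 nM.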

Compound 4, half-maximal inhibitory concentration: 12600 nM
Estimate against measurement, compound 4: 1.1-fold (0.05 log units) above; the measured number falls inside the stated range.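

In this assay, trifluoromethoxy in place of trifluoromethyl on the second core gave a 1.7-fold lower number from compound 3 to compound 4 (0.22 log units; within the scatter). Set beside the earlier step, the change carried from one core to the other with no difference that the data can resolve: the same change on two cores in this assay, a 1.6-fold lower number (0.19 log units; within the scatter) from compound 1 to compound 2 and a 1.7-fold lower number (0.22 log units; within the scatter) from compound 3 to compound 4, 1.1-fold (0.03 log units) apart, within the scatter of two such steps. Each step alone lies within the scatter, so this agreement does not establish a real effect of the change, and two cores cannot speak for the whole series.

The compounds shown leave open whether another group on that aromatic carbon, such as a nitrile or a carboxylic acid, would give a step beyond the scatter. They also leave open how an amine in place of the hydroxyl would behave.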